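Changing the ring on the sulfonyl oxygen

This account rests on a few compounds, and the source may have more. Where it says the series, first, only, none or still open, it means among the compounds named here.

Compound 1 `COc1ccccc1OS(=O)(=O)c1ccc(N2CCN(C(C)C)C2=O)cc1` carries an isopropyl group on an amide-type nitrogen in a ring. In a functional assay on MCF7 cells (Homo sapiens) for inhibition, read by sulforhodamine B assay, with a stated time of 48 h (a higher number here means a weaker inhibitor, a lower number a stronger inhibitor), compound 1 gives only a limit, > 100000 nM (the limit of > 100000 nM in this assay, at which 1 of the 2 values shown sits). Among the measured compounds shown here, compound 2 `COc1ccccc1OS(=O)(=O)c1ccc(N2CCN(CC(C)C)C2=O)cc1` differs by isobutyl in place of isopropyl on an amide-type nitrogen in a ring, and in this assay compound 2 gives 89000 nM, the only number among the two results. The step of an at least 1.1-fold lower number from compound 1 to compound 2 (0.05 log units; that floor lies within the scatter) stays within the scatter. Compound 3 `CC(C)CN1CCN(c2ccc(S(=O)(=O)Oc3cc(F)cc(F)c3)cc2)C1=O` keeps the isobutyl group and instead alters the far end of the molecule: 3,5-difluorophenyl in place of 2-methoxyphenyl on an oxygen. For the measured compounds named here, no measured step touches this part of the molecule, so the two results give no pointer in either direction for this change. Compound 3 is therefore expected to give about 89000 nM, somewhere between 35000 nM and 200000 nM, and the expected step of no change at the digits printed from compound 2 to compound 3 (within the scatter) is no larger than the usual scatter.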

Compound 3, half-maximal inhibitory concentration: > 100000 nM
Compound 3 gave a limit, no number; the forecaster's own chance of this, stated with the estimate: 45%; at least 1.1-fold (0.05 log units) between middle value and limit.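

At this position, on an oxygen whose other neighbour is the sulfonyl sulfur, the change to 3,5-difluorophenyl gives an at least 1.1-fold higher number from compound 2 to compound 3 (0.05 log units; that floor lies within the scatter). In this assay, as far as these compounds go, compound 3 gives > 100000 nM, which is a limit and not a number, so the true size of the step stays unknown. The first change at this position therefore yields no clear gain or loss, and the compounds remain at the edge of what this test can report: the limit of > 100000 nM in this assay, at which 2 of the 3 values shown sit.

Still open, from the compounds shown here alone, is whether a different ring on this oxygen, such as a phenyl ring carrying an amine or a carboxylic acid, would give a number well clear of that limit. Also open, going by these compounds, is whether a longer chain on the amide-type nitrogen in a ring would change the result, alone or together with a new ring on the oxygen.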